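A few compounds are considered here, and "the series" means these few. Any claim that something is new, unique, unknown or untested is made for them only; others in the source may bear on it.

Series notes, measured compounds:

compound 1 `FC(F)(F)c1ccccc1-c1nc(NCc2ccccc2)c2ccccc2n1` — 3100 nM in an assay on a protein complex for inhibition of ubiquitin carboxyl-terminal hydrolase 1/WD repeat-containing protein 48 (Homo sapiens), read by fluorescence; a higher number here means a weaker inhibitor, a lower number a stronger inhibitor
compound 2 `COc1ccc(CNc2nc(-c3ccccc3C(F)(F)F)nc3ccccc23)cc1` — 6200 nM in this assay
compound 3 `FC(F)(F)c1ccccc1-c1nc(NCc2ccc(-c3ccccc3)cc2)c2ccccc2n1` — 3700 nM in this assay

Compound 1 gives the lowest of the three numbers, but all three sit within the scatter of one another: a 2.0-fold higher number from compound 1 to compound 2 (0.30 log units; within the scatter) and a 1.2-fold higher number from compound 1 to compound 3 (0.08 log units; within the scatter); likewise a 1.7-fold lower number from compound 2 to compound 3 (0.22 log units; within the scatter). So no compound here can be called stronger or weaker than another.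

Compound 4 `FC(F)(F)c1ccccc1-c1nc(NCc2ccc(-c3ccncc3)cc2)c2ccccc2n1` is not yet measured. Its change from compound 1 is pyridin-4-yl in place of hydrogen on an aromatic carbon. For the measured compounds named here, the closest precedent is compound 3, where a phenyl entered at the same aromatic carbon and moved the number only within the scatter. A six-membered aromatic ring with one nitrogen in that position is expected to behave much the same, so in this assay no step beyond the scatter is expected: a 1.1-fold higher number from compound 1 to compound 4 (0.05 log units; within the scatter). The estimate for compound 4 is 3500 nM, with a range of 1500 nM to 8000 nM.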

Compound 4, half-maximal inhibitory concentration: 1900 nM
Beside the measured number, compound 4's estimate is 1.8-fold (0.27 log units) above it; the range from low to high includes it.
By their numbers in this assay, from the lowest: compounds 4, 1, 3 and 2 (each within the scatter of the next, the first and the last beyond it).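

The series now holds its first step beyond the scatter at this aromatic carbon, para to a large group: a 3.3-fold lower number from compound 2 to compound 4 (0.51 log units; beyond the scatter) in this assay, a modest gap. Pyridin-4-yl does not separate compound 4 from the unsubstituted or phenyl analogues, as both a 1.6-fold lower number from compound 1 to compound 4 (0.21 log units; within the scatter) and a 1.9-fold lower number from compound 3 to compound 4 (0.29 log units; within the scatter) remain small. Nothing measured here accounts for these steps.

As far as these compounds go, whether an amine or a carboxylic acid at this carbon would give a step beyond the scatter from compound 1 remains open. Also open, from the compounds shown here alone, is how pyridin-4-yl behaves when trifluoromethyl is replaced by another group.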